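The source may report more compounds than this note shows. Statements on the series, on what has been measured and on what is new or still open speak of the compounds shown alone.

Two measured compounds share one core and differ at a single place. Compound 1 `Cc1ccc2nc(C(=O)Nc3c(F)cc(-c4cccc(F)c4)cc3F)c(C)c(C(=O)O)c2c1` carries hydrogen on a saturated chain carbon bound to an aromatic carbon; in a functional assay on A-375 cells (Homo sapiens) for antiproliferative activity, read by MTT assay, with a stated time of 24 h, tested at 0.14 ug/mL (on this read-out higher numbers stand for a stronger effect at the one concentration tested and lower numbers for a weaker effect), compound 1 gives 0.98%. Compound 2 `CCc1ccc2nc(C(=O)Nc3c(F)cc(-c4cccc(F)c4)cc3F)c(C)c(C(=O)O)c2c1` has methyl in place of that hydrogen, and in this assay compound 2 gives 2.45%. For the measured compounds named here, the one step measured, a number 1.5 percentage points higher from compound 1 to compound 2 (within the scatter), is within the scatter, so the two numbers cannot be separated. Compound 2 therefore stands nominally highest of the two numbers shown, but its nearest neighbour, compound 1, lies within the scatter of it and no order can be claimed. Both numbers sit close to zero.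

Compound 3 `Cc1c(C(=O)Nc2c(F)cc(-c3cccc(F)c3)cc2F)nc2ccc(F)cc2c1C(=O)O` is not yet measured. It differs from compound 2 by fluoro in place of ethyl on an aromatic carbon. Going by the values given here, no measured step touches an aromatic carbon of the core; the only step available, a number 1.5 percentage points higher from compound 1 to compound 2 (within the scatter), concerns a saturated chain carbon and was within the scatter. The expected step is thus a number 0.5 percentage points lower from compound 2 to compound 3 (within the scatter), with no change beyond the scatter foreseen. The estimate for compound 3 in this assay is 2%, with a range from -8% to 12%.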

Compound 3, a percentage reported as inhibition, at one concentration (the size of the read-out at that concentration, not a potency): 1.05%
Compound 3: middle estimate off by 1 percentage points, on the high side, and the stated range covers the measured number.
By their numbers in this assay, from the lowest: compounds 1, 3 and 2 (each within the scatter of the next).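

At this position on an aromatic carbon of the shared core, the earlier pair had shown only a change from one carbon chain to another, whereas fluoro now replaces the chain. In this assay, the swap of ethyl for fluoro gives a number 1.4 percentage points lower from compound 2 to compound 3 (within the scatter) and the swap of methyl for fluoro gives a number 0.1 percentage points higher from compound 1 to compound 3 (within the scatter) on the same read-out. Methyl, ethyl and fluoro at this place therefore cannot be told apart, and replacing a chain with a single fluorine atom produces no change that can be separated from the scatter; nothing available accounts for this flat result.

Going by these compounds, it remains open whether any other group at this place, such as an amine, a methoxy group, a carboxylic acid or a longer chain like butyl, would move the read-out clear of the scatter and away from zero. On these data alone, with a single concentration and a single time in this assay, it also remains open whether these three compounds would separate at a higher concentration or after a longer exposure.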